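Swapping fluoro for chloro in compound 2

A few compounds are considered here, and "the series" means these few. Any claim that something is new, unique, unknown or untested is made for them only; others in the source may bear on it.

- Compound 1 `Cc1ccc(C(=O)Nc2ccc(C#N)cc2)c(O)c1` gives 2420 nM
- Compound 2 `N#Cc1ccc(NC(=O)c2ccc3cccnc3c2O)c(F)c1` gives 730 nM

In a functional assay on HL-60 cells (Homo sapiens) for cytotoxicity, read by luminescence and CellTiter-Glo, with a stated time of 3 days (on this read-out lower numbers stand for stronger inhibition and higher numbers for weaker inhibition), compound 2 gives 730 nM and holds the lower of the two numbers, while compound 1 at 2420 nM sits higher by more than the usual scatter. Compound 3 `N#Cc1ccc(NC(=O)c2ccc3cccnc3c2O)c(Cl)c1` differs from compound 2 in one place, with chloro in place of fluoro on an aromatic carbon. Among the compounds with values here, no measured pair shows this swap, so no step beyond the scatter is expected in this assay. The expected change is a 1.1-fold lower number from compound 2 to compound 3 (0.05 log units; within the scatter) and stays within that scatter. Compound 3 is estimated at 650 nM (270 nM to 1600 nM).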

Compound 3, half-maximal inhibitory concentration: 910 nM
Compound 3: the middle estimate sits 1.4-fold (0.15 log units) below what was measured; low and high end bracket the measured number.
By their numbers in this assay, from the lowest: compounds 2 and 3 (each within the scatter of the next); then compound 1.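

In this assay the swap of fluoro for chloro, on an aromatic carbon ortho to a large group and meta to a cyano group, gives a 1.2-fold higher number from compound 2 to compound 3 (0.10 log units; within the scatter) and so leaves the two compounds indistinguishable. Within the data shown here, this is the first view of a single change at this position, and it shows that these two halogens cannot be told apart here. Nothing measured alongside these numbers offers an explanation for this result. On these data alone, whether an amine or a methoxy group at this position would shift the number remains open.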